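Spiro thiazine anilines: trifluoromethyl to methoxy swap

A few compounds are considered here, and "the series" means these few. Any claim that something is new, unique, unknown or untested is made for them only; others in the source may bear on it.

Measured so far:
- compound 1, `FC(F)(F)c1ccc(NC2=NCCC3(CCCCC3)S2)cc1`: 77600 nM
- compound 2, `Cc1cc(C)c(NC2=NCCC3(CCCCC3)S2)c(C)c1`: 9300 nM

In a functional assay on a subcellular fraction from brain (Rattus norvegicus) for inhibition, read by scintillation counting, with a stated time of 5 min (a lower number here means a stronger inhibitor, a higher number a weaker inhibitor), compound 1 gives 77600 nM, the highest number of the two. Compound 2 sits next, with a lower number, a gap beyond the scatter. Nothing more can be read from the pair, since the two compounds differ in more than one place.

Compound 3, `COc1ccc(NC2=NCCC3(CCCCC3)S2)cc1`, is the next point in this assay and is not yet measured. It differs from compound 1 by a single change, methoxy in place of trifluoromethyl on an aromatic carbon, para to a large group. Within the data shown here, no matched step covers this swap, so the size of the move is uncertain. Compound 2 shows that the shared core can reach a lower number, and a shift downward of modest size, beyond the scatter but not large, is expected for compound 3.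

Compound 3 is estimated at 30000 nM, between 8000 nM and 120000 nM, a step from compound 1 of a 2.6-fold lower number from compound 1 to compound 3 (0.41 log units; beyond the scatter) expected.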

Compound 3, half-maximal inhibitory concentration: 85100 nM
The estimate for compound 3 lay 2.8-fold (0.45 log units) below the measured number; the measured number falls inside the stated range.
By their numbers in this assay, from the lowest: compound 2; then compounds 1 and 3 (each within the scatter of the next).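

In this assay, among these compounds, the first matched step gives a 1.1-fold higher number from compound 1 to compound 3 (0.04 log units; within the scatter), so trifluoromethyl and methoxy cannot be told apart on this aromatic carbon, para to a large group. On this pair, the hydrogen-bond acceptor counted for methoxy and absent from trifluoromethyl goes with no readable difference in the number, and neither does the smaller heavy-atom count of methoxy. No measured property on hand accounts for this result.

Compound 2 differs from compound 1 and compound 3 in more than one place, so its steps to them cannot be read, and its lower number cannot be assigned to any single feature of its substitution. As far as these compounds go, it remains open whether any group at this position can move the number beyond the scatter, for instance an amine, a carboxylic acid or a longer chain such as butoxy, since two groups on one aromatic carbon give no trend.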